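Removing the ester side chain from compound 3

The source may report more compounds than this note shows. Statements on the series, on what has been measured and on what is new or still open speak of the compounds shown alone.

Measured in a functional assay on SEM cells (Homo sapiens) for cytotoxicity, with a stated time of 72 h; a lower number here means that less compound is needed, a higher number that more compound is needed for the effect:
- compound 1 `C=C[C@@](C)(/C=C/c1ccc(O)cc1)CC/C=C(\C)CO`: > 36600 nM
- compound 2 `C=C[C@@](C)(/C=C/c1ccc(O)c(/C=C/c2ccc(Cl)c(Cl)c2)c1)CCC=C(C)C`: > 7500 nM
- compound 3 `COc1ccc(/C=C/[C@@](C)(/C=C/c2ccc(O)c(/C=C/C(=O)OC(C)(C)C)c2)CCC=C(C)C)cc1`: > 36600 nM

Each entry is a limit of the assay, not a number. Compound 3 gives only a limit, > 36600 nM. Compound 4 `COc1ccc(/C=C/[C@@](C)(/C=C/c2ccc(O)cc2)CCC=C(C)C)cc1` carries hydrogen in place of 2-(tert-butoxycarbonyl)ethenyl on an aromatic carbon, ortho to a hydroxy group: hydrogen in place of 2-(tert-butoxycarbonyl)ethenyl on an aromatic carbon. Among the measured compounds shown here, no measured step shows what this change does. The expectation rests on compound 1, which also lacks that group and gives > 36600 nM, again a limit. The expected at least 1.2-fold lower number from compound 3 to compound 4 (0.08 log units; that floor lies within the scatter) in this assay is no larger than the scatter, with no clear direction. Compound 4 is expected at 30000 nM, with an estimated range of 12000 nM to 60000 nM.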

Compound 4, half-maximal effective concentration: > 36600 nM
Compound 4: no number, only a limit; the forecaster's own chance of this, stated with the estimate: 75%; middle value at least 1.2-fold (0.08 log units) from the limit.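

Compound 3 is a limit of the assay, > 36600 nM. Compound 4 is also only a limit, > 36600 nM, so the step between these two compounds cannot be read. The compounds shown leave open whether any change to the shared core gives a number rather than a limit in this assay.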